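A few compounds are considered here, and "the series" means these few. Any claim that something is new, unique, unknown or untested is made for them only; others in the source may bear on it.

The measured compounds and their values:

Compound 1, `N#Cc1c(Cl)nc(SCC(=O)Nn2c(COc3ccc(Cl)cc3Cl)nc3ccccc3c2=O)nc1-c1ccccc1`: 60%
Compound 2, `N#Cc1c(Cl)nc(SCC(=O)Nn2c(COc3ccc(Cl)cc3Cl)nc3ccccc3c2=O)nc1-c1ccc(Cl)cc1`: 63.6%
Compound 3, `N#Cc1c(Nc2ccccc2)nc(SCC(=O)Nn2c(COc3ccc(Cl)cc3Cl)nc3ccccc3c2=O)nc1-c1ccccc1`: 77.3%

All three were tested in a functional assay on the whole organism (strain albino) for inhibition, with Rattus norvegicus as the target, read by paw edema, with a stated time of 1 h, at a dose of 100 mg/kg by the oral route; a lower number here means less inhibition, a higher number more inhibition at the dose given (going by the name of the read-out). Compound 3 gives the highest of the three numbers, and its lead over the others is beyond the scatter: a number 17.3 percentage points higher from compound 1 to compound 3 (beyond the scatter), while compound 2 lies 63.6%. Compound 3 therefore stands apart with the highest number of the three measured.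

Compound 4, `N#Cc1c(Nc2ccccc2)nc(SCC(=O)Nn2c(COc3ccc(Cl)cc3Cl)nc3ccccc3c2=O)nc1-c1ccc(Cl)cc1`, has not yet been measured. It differs from compound 3 in one place: chloro in place of hydrogen on an aromatic carbon. Seen one bond further out, the phenyl of compound 3 becomes a 4-chlorophenyl in compound 4.

Among the measured compounds shown here, one measured step bears directly on this change, because the same exchange was made on the chloro-bearing analogue: a number 3.6 percentage points higher from compound 1 to compound 2 (within the scatter). That step stayed within the scatter, so the exchange of hydrogen for chloro on that ring made no clear difference in this assay there. On that basis no step beyond the scatter is expected here either: the change is estimated as a number 1.7 percentage points higher from compound 3 to compound 4 (within the scatter). Compound 4 is therefore expected to give about 79% in this assay, with a likely range from 68% to 90%.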

Compound 4, a percentage reported as inhibition, in the whole organism at one dose (the size of the read-out at that dose, not a potency): 43.6%
Compound 4: middle estimate off by 35.4 percentage points, on the high side, and the stated range ends above it.
By their numbers in this assay, from the lowest: compound 4; then compounds 1 and 2 (each within the scatter of the next); then compound 3.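

In this assay, the change from phenyl to 4-chlorophenyl has no single effect: with the anilino group on the core it gives a number 33.7 percentage points lower from compound 3 to compound 4 (beyond the scatter), and the outcome depends on which group sits at the other changed place, as the two matched comparisons show: the same change on two cores in this assay, a number 3.6 percentage points higher (within the scatter) from compound 1 to compound 2 and a number 33.7 percentage points lower (beyond the scatter) from compound 3 to compound 4, 37.3 percentage points apart, beyond the scatter of two such steps

The anilino exchange reverses direction in the same way, giving a number 20 percentage points lower from compound 2 to compound 4 (beyond the scatter) once the 4-chlorophenyl is present: the same change on two cores in this assay, a number 17.3 percentage points higher (beyond the scatter) from compound 1 to compound 3 and a number 20 percentage points lower (beyond the scatter) from compound 2 to compound 4, 37.3 percentage points apart, beyond the scatter of two such steps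

The two places therefore do not act independently in this set, so the result of a change at one cannot be carried over to a compound with a different group at the other.

On these data alone, it remains open whether this reversal is specific to chloro or would also appear with another group on that ring, such as fluoro or methoxy, and whether a different amine, such as morpholine, would behave like anilino. The compounds shown also give no explanation of why the two places are linked, and four compounds cannot show how far the pattern extends.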